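Swapping a sulfonamide for a benzamide on the linker

The compounds below may be only part of what the source reports. "The series", "measured", "known", "first", "only" and "open" are said of these compounds alone.

Compound 2 `Cc1ccc(S(=O)(=O)NCCCNc2nccc(-c3c(-c4cccc(F)c4)nc4sccn34)n2)cc1` and compound 1 `O=S(=O)(NCCNc1nccc(-c2c(-c3cccc(F)c3)nc3sccn23)n1)c1ccc(Br)cc1` share a core and differ by one change. In a functional assay on SK-MEL-28 cells (Homo sapiens) for cytotoxicity, read by MTT assay (on this read-out higher numbers stand for weaker inhibition and lower numbers for stronger inhibition), compound 1 gives 13500 nM and compound 2 gives 9500 nM; the step of a 1.4-fold lower number from compound 1 to compound 2 (0.15 log units; within the scatter) leaves the two within the scatter of each other. Compound 3 `O=C(NCCNc1nccc(-c2c(-c3cccc(F)c3)nc3sccn23)n1)c1ccccc1` carries benzamido in place of (((4-methylphenyl)sulfonyl)amino)methyl on a saturated chain carbon, two bonds along the chain from a nitrogen on an aromatic ring. Going by the values given here, no measured step covers this swap, and the one known step was small, so only a modest change is expected: a 1.2-fold higher number from compound 2 to compound 3 (0.06 log units; within the scatter). Compound 3 is therefore estimated at 11000 nM, with a range of 4000 nM to 30000 nM.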

Compound 3, half-maximal inhibitory concentration: 17000 nM
Estimate against measurement, compound 3: 1.5-fold (0.19 log units) below, and the stated range covers the measured number.
By their numbers in this assay, from the lowest: compounds 2, 1 and 3 (each within the scatter of the next).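

In this assay an amide link does as a sulfonamide link did: benzamido in place of (((4-methylphenyl)sulfonyl)amino)methyl gives a 1.8-fold higher number from compound 2 to compound 3 (0.25 log units; within the scatter) and benzoyl in place of (4-bromophenyl)sulfonyl on an amine nitrogen gives a 1.3-fold higher number from compound 1 to compound 3 (0.10 log units; within the scatter) and so all three compounds stay within the scatter of one another. This position has therefore now taken two different links without a step beyond the scatter. Nothing available explains this result. As far as these compounds go, it remains open whether an amine or a carboxylic acid in place of the benzamido group would give a number clearly apart from these three.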